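Adding one fluoro to the phenyl of compound 3

The source may report more compounds than this note shows. Statements on the series, on what has been measured and on what is new or still open speak of the compounds shown alone.

Measured so far in a functional assay on SW-620 cells (Homo sapiens) for cytotoxicity, read by MTT assay, with stated times of 4 h and 72 h, tested at 2 uM; a lower number here means a stronger inhibitor, a higher number a weaker inhibitor:
- Compound 1 `COc1ccc(/C=C/C(=O)c2ccc(Nc3cc(C)nc4nc(SCc5nc6ccccc6[nH]5)nn34)cc2)cc1F`: 140 nM
- Compound 2 `COc1ccc(/C=C/C(=O)c2ccc(Nc3cc(C)nc4nc(SCc5nc6ccccc6[nH]5)nn34)cc2)cc1`: 170 nM
- Compound 3 `Cc1cc(Nc2ccc(C(=O)/C=C/c3ccccc3)cc2)n2nc(SCc3nc4ccccc4[nH]3)nc2n1`: 130 nM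

Compound 3, at 130 nM, cannot be told apart from the other two, since all its steps lie within the scatter. Compound 4 `Cc1cc(Nc2ccc(C(=O)/C=C/c3ccccc3F)cc2)n2nc(SCc3nc4ccccc4[nH]3)nc2n1` differs from it by one change: fluoro in place of hydrogen on an aromatic carbon, ortho to a large group. The closest evidence is a 1.2-fold higher number from compound 1 to compound 2 (0.08 log units; within the scatter), where hydrogen replaces fluoro on an aromatic carbon. Two wider changes, a 1.1-fold lower number from compound 1 to compound 3 (0.03 log units; within the scatter) and a 1.3-fold lower number from compound 2 to compound 3 (0.12 log units; within the scatter), also stay within the scatter. The expected 1.1-fold higher number from compound 3 to compound 4 (0.03 log units; within the scatter) in this assay is therefore none beyond the scatter. Compound 4 is estimated at 140 nM, with an expected range of 75 nM to 270 nM.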

Compound 4, half-maximal inhibitory concentration: 250 nM
Estimate against measurement, compound 4: 1.8-fold (0.25 log units) below; low and high end bracket the measured number.
By their numbers in this assay, from the lowest: compounds 3, 1, 2 and 4 (each within the scatter of the next).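

With fluoro ortho to a large group, the phenyl of compound 3 gives a 1.9-fold higher number from compound 3 to compound 4 (0.28 log units; within the scatter), the largest step in this set, yet one that still cannot be separated from assay noise. Replacing the other two substituted phenyl groups with 2-fluorophenyl gives a 1.5-fold higher number from compound 2 to compound 4 (0.17 log units; within the scatter) and a 1.8-fold higher number from compound 1 to compound 4 (0.25 log units; within the scatter), so this group is not set apart from them either. Fluoro in place of hydrogen can now be compared on two cores, and the two results cannot be told apart: the same change on two cores in this assay, a 1.2-fold higher number (0.08 log units; within the scatter) from compound 1 to compound 2 and a 1.9-fold lower number (0.28 log units; within the scatter) from compound 4 to compound 3, 2.3-fold (0.37 log units) apart, within the scatter of two such steps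

Still open, on these data alone, is whether an amine or a carboxylic acid on this same carbon would give a step beyond the scatter.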